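The source may hold more compounds than are shown below. What is called first, only, known or untested is meant among the compounds shown, and "the series" means these compounds.

Compound 3 `CN(C)CCn1cnnc1-c1cc(Oc2ccc(NC(=O)N/N=C/c3ccc(O)c(F)c3)cc2F)ccn1` gives 1970 nM in a functional assay on MKN-45 cells (Homo sapiens) for cytotoxicity, read by MTT assay, with a stated time of 72 h; a lower number here means a stronger inhibitor, a higher number a weaker inhibitor. That places it second highest of the three numbers: compound 1 `CN(C)CCn1cnnc1-c1cc(Oc2ccc(NC(=O)N/N=C/c3ccccc3)cc2F)ccn1` gives 2730 nM, and the step of a 1.4-fold lower number from compound 1 to compound 3 (0.14 log units; within the scatter) stays within the scatter, while compound 2 `CN(C)CCn1cnnc1-c1cc(Oc2ccc(NC(=O)N/N=C/c3ccc(F)cc3F)cc2F)ccn1` gives 810 nM, and the step of a 2.4-fold higher number from compound 2 to compound 3 (0.39 log units; beyond the scatter) lies beyond it. Compound 4 `COc1cc(/C=N/NC(=O)Nc2ccc(Oc3ccnc(-c4nncn4CCN(C)C)c3)c(F)c2)ccc1O` differs from compound 3 by methoxy in place of fluoro on an aromatic carbon. Going by the values given here, no measured step swaps these two groups; the steps that bear on this ring are a 3.4-fold lower number from compound 1 to compound 2 (0.53 log units; beyond the scatter) and a 1.4-fold lower number from compound 1 to compound 3 (0.14 log units; within the scatter), both changes of substitution on the same aromatic ring and both modest at most. For compound 4 a step of a 1.0-fold higher number from compound 3 to compound 4 (0.01 log units; within the scatter) is therefore expected, nothing beyond the scatter. Compound 4 is estimated at 2000 nM, within 800 nM to 5000 nM.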

Compound 4, half-maximal inhibitory concentration: 3780 nM
For compound 4 the middle estimate is 1.9-fold (0.28 log units) below the measured one; measured number inside the range.
By their numbers in this assay, from the lowest: compound 2; then compounds 3, 1 and 4 (each within the scatter of the next).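

In this assay, going by these compounds alone, the first direct swap at this position, methoxy in place of fluoro ortho to a hydroxy group, gives a 1.9-fold higher number from compound 3 to compound 4 (0.28 log units; within the scatter) and so leaves the number within the scatter, and a 1.4-fold higher number from compound 1 to compound 4 (0.14 log units; within the scatter) likewise does not separate the 4-hydroxy-3-methoxyphenyl group from plain phenyl. Among the rings shown, only 2,4-difluorophenyl stands apart from it, and a 4.7-fold higher number from compound 2 to compound 4 (0.67 log units; beyond the scatter) is the one new step beyond the scatter. No measurement shown bears on the cause of these results. On these data alone, whether ethoxy or an amine at this position would move the number beyond the scatter stays open, as does the effect of removing the hydroxy group while keeping the methoxy.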